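Aryl replacement on two cytotoxicity limits in this series

A few compounds are considered here, and "the series" means these few. Any claim that something is new, unique, unknown or untested is made for them only; others in the source may bear on it.

Measured in a functional assay on MGC-803 cells (Homo sapiens) for cytotoxicity, read by MTT assay, with a stated time of 72 h; on this read-out higher numbers stand for weaker inhibition and lower numbers for stronger inhibition:
compound 1 `CCCCCCCCCCCCNc1nc(SCc2ccc(C(F)(F)F)cc2)nc2ccccc12` gives > 50000 nM, a limit of the assay.
compound 2 `FC(F)(F)c1ccc(CSc2nc(Nc3ccccc3Cl)c3ccccc3n2)cc1` gives > 50000 nM, a limit of the assay.

Compound 2 stands at the limit of the assay, with no numerical potency; the same holds for compound 1, as the limit of > 50000 nM in this assay, at which 2 of the 2 values shown sit, records, so neither value orders the pair. Within the data shown here, no step between measured compounds is available. Compound 3 `Fc1ccc(Nc2nc(SCc3ccc(C(F)(F)F)cc3)nc3ccccc23)cc1` differs from compound 2 by 4-fluorophenyl in place of 2-chlorophenyl on a nitrogen on an aromatic ring. With both measured values sitting at the limit, no direction for this change can be read from the data, and the expected step that the limit leaves unreadable from compound 2 to compound 3 in this assay is an expectation without measured support. Compound 3 is estimated at 60000 nM, within 10000 nM to 300000 nM, most likely reported again as a limit.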

Compound 3, half-maximal inhibitory concentration: 9620 nM
Compound 3: middle estimate off by 6.2-fold (0.79 log units), on the high side, and the stated range ends above it.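

In this assay, 4-fluorophenyl in place of 2-chlorophenyl on a nitrogen on an aromatic ring gives an at least 5.1-fold lower number from compound 2 to compound 3 (0.71 log units; beyond the scatter). The aryl group at this nitrogen can therefore take the series off the limit, which compound 1 and compound 2 could not show, and compound 3 gives the series its first numerical potency as a reference for further changes at this position. The size of the step remains a bound only, because compound 2 carries a limit and not a number: the limit of > 50000 nM in this assay, at which 2 of the 3 values shown sit.

The compounds shown do not separate the change of halogen from the change of its place on the phenyl ring. They also leave open how a plain phenyl, a pyridyl ring or a benzyl group on that nitrogen would read in this assay.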